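Replacing a chlorophenyl ether with a trifluoromethylphenyl ether

The source may report more compounds than this note shows. Statements on the series, on what has been measured and on what is new or still open speak of the compounds shown alone.

Measured so far in a functional assay on MIA PaCa-2 cells (Homo sapiens) for antiproliferative activity, read by MTT assay, with a stated time of 72 h; a higher number here means that more compound is needed for the effect, a lower number that less compound is needed:
Compound 1, `CNC(=O)c1cccc(Cn2nc(C)c(NC(=O)c3ccc(COc4ccccc4)cc3)c2C)c1`, gives 6200 nM.
Compound 2, `CNC(=O)c1cccc(Cn2nc(C)c(NC(=O)c3ccc(COC4CCCCC4)cc3)c2C)c1`, gives 14000 nM.
Compound 3, `CNC(=O)c1cccc(Cn2nc(C)c(NC(=O)c3ccc(COc4ccc(Cl)cc4)cc3)c2C)c1`, gives 4200 nM.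

All three share one core and differ only in the group hung on the oxygen of the ether. For the measured compounds named here, compound 3 carries the lowest number of the three, but its gap to compound 1 lies within the scatter, as the step of a 1.5-fold lower number from compound 1 to compound 3 (0.17 log units; within the scatter) shows; only the step of a 3.3-fold lower number from compound 2 to compound 3 (0.52 log units; beyond the scatter) is beyond the scatter, and the step of a 2.3-fold higher number from compound 1 to compound 2 (0.35 log units; beyond the scatter) points the same way.

Compound 4, `CNC(=O)c1cccc(Cn2nc(C)c(NC(=O)c3ccc(COc4cccc(C(F)(F)F)c4)cc3)c2C)c1`, is the next step: 3-(trifluoromethyl)phenyl in place of 4-chlorophenyl on an oxygen on a saturated carbon. Going by the values given here, the aromatic ring stays, so the one step that did matter, the swap from a saturated to an aromatic ring, does not bear on it; the only comparable change, the chloro added in compound 3, stayed within the scatter. A change of no more than the scatter is therefore expected, and compound 4 is estimated at 5000 nM, between 2000 nM and 12000 nM, a step of a 1.2-fold higher number from compound 3 to compound 4 (0.08 log units; within the scatter) that is expected to stay small.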

Compound 4, half-maximal effective concentration: 2300 nM
Compound 4: the middle estimate sits 2.2-fold (0.34 log units) above what was measured, within the range that was stated.
By their numbers in this assay, from the lowest: compounds 4, 3 and 1 (each within the scatter of the next, the first and the last beyond it); then compound 2.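

In this assay, a 2.7-fold lower number from compound 1 to compound 4 (0.43 log units; beyond the scatter), so trifluoromethyl on the phenyl ring gives a step beyond the scatter, which the chloro of compound 3 did not. Even so, a 1.8-fold lower number from compound 3 to compound 4 (0.26 log units; within the scatter), so compound 3 and compound 4 cannot be ranked, and this swap alters both the substituent and its place on the ring, leaving those two changes unseparated. The gap to the saturated ring also widens: a 6.1-fold lower number from compound 2 to compound 4 (0.78 log units; beyond the scatter), the largest step among these compounds.

Nothing available explains these differences. Also open, on these data alone, is how the number would respond to other groups on the phenyl ring, such as a methoxy group or a nitrile, and whether any of them would take it clearly lower than compound 4 does.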